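Hydroxy for ethyl on the triazole side chain

The compounds below may be only part of what the source reports. "The series", "measured", "known", "first", "only" and "open" are said of these compounds alone.

Measured compounds:
Compound 1 `Cc1ccc(-c2cn(C/C=C3\OC(=O)C(OCc4ccccc4)=C3OCc3ccccc3)nn2)cc1`: in a functional assay on CFPAC-1 cells (Homo sapiens) for antiproliferative activity, read by MTT assay, with a stated time of 72 h (a lower number here means a stronger inhibitor, a higher number a weaker inhibitor), compound 1 reaches only the assay limit of > 100000 nM.
Compound 2 `CCCCCc1ccc(-c2cn(C/C=C3\OC(=O)C(OCc4ccccc4)=C3OCc3ccccc3)nn2)cc1`: in this assay compound 2 likewise reaches only the assay limit of > 100000 nM.
Compound 3 `CCCCc1cn(C[C@H](O)[C@H]2OC(=O)C(OCc3ccccc3)=C2OCc2ccccc2)nn1`: in this assay compound 3 gives 73200 nM.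

The step that the two limits leave unreadable from compound 1 to compound 2 cannot be read, since both ends sit at the limit described by the limit of > 100000 nM in this assay, at which 2 of the 3 values shown sit. Among the measured compounds shown here, compound 3 therefore stands as the only compound of the three with an actual number, and that number is itself a weak one.

Compound 4 `O=C1O[C@H]([C@@H](O)Cn2cc(CCO)nn2)C(OCc2ccccc2)=C1OCc1ccccc1` differs from compound 3 by hydroxy in place of ethyl on a saturated chain carbon, two bonds along the chain from an aromatic carbon. No measured step touches this change: the one step that is shown, a step that the two limits leave unreadable from compound 1 to compound 2, concerns a different position and is unreadable in any case, so there is nothing here to say whether the change should strengthen or weaken the inhibition. The expectation for compound 4 therefore rests on compound 3 alone and on the fact that two of three values sit at the limit (the limit of > 100000 nM in this assay, at which 2 of the 3 values shown sit).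

Compound 4 is expected to give 100000 nM in this assay, within 30000 nM to 300000 nM. That estimate means a step of a 1.4-fold higher number from compound 3 to compound 4 (0.14 log units; within the scatter), not beyond the scatter, with a real chance that only a limit is reported.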

Compound 4, half-maximal inhibitory concentration: > 100000 nM
Compound 4 was reported as a limit; the forecaster's own chance of this, stated with the estimate: 50%; the middle value lies on the limit itself.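

In this assay, among the compounds shown here, the change from 4-butyl-1H-1,2,3-triazol-1-yl to 4-(2-hydroxyethyl)-1H-1,2,3-triazol-1-yl gives the first step that can be read at all, and it reads an at least 1.3-fold higher number from compound 3 to compound 4 (0.13 log units; that floor lies within the scatter). That is only a floor, so it shows no real loss of activity, but it does show that hydroxy in place of ethyl at this place brings no gain the assay can register, since the result for compound 4 is a limit and not a number. For the compounds shown here, compound 3, which carries the butyl group, thus remains the only compound with an actual number, and the other compounds, whether they carry this side chain or the aryl-substituted one, end at the same limit: the limit of > 100000 nM in this assay, at which 3 of the 4 values shown sit.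

On these data alone, how far beyond the limit compound 4 lies stays open, so the true size of this step could be small or large. Also open, as far as these compounds go, is whether a longer chain, an amine or a carboxylic acid on the triazole side chain would give a stronger inhibitor than compound 3 with its 73200 nM.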